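Replacing Bromophenyl with Hydroxy-Methoxyphenyl in a Cytotoxic Series

The compounds below may be only part of what the source reports. "The series", "measured", "known", "first", "only" and "open" are said of these compounds alone.

Compound 1 `CN(C)CCn1cnnc1-c1cc(Oc2ccc(NC(=O)N/N=C/c3cccc(Br)c3)cc2F)ccn1` gives 380 nM in a functional assay on HT-29 cells (Homo sapiens) for cytotoxicity, read by MTT assay, with a stated time of 72 h; a higher number here means a weaker inhibitor, a lower number a stronger inhibitor. Among the three measured compounds it holds the middle place: compound 2 `CN(C)CCn1cnnc1-c1cc(Oc2ccc(NC(=O)N/N=C/c3cccc(Cl)c3Cl)cc2F)ccn1` gives 130 nM, a step of a 2.9-fold lower number from compound 1 to compound 2 (0.47 log units; beyond the scatter), while compound 3 `COc1ccc(/C=N/NC(=O)Nc2ccc(Oc3ccnc(-c4nncn4CCN(C)C)c3)c(F)c2)c(OC)c1OC` gives 3970 nM, a step of a 10-fold higher number from compound 1 to compound 3 (1.02 log units; beyond the scatter). Compound 4 `COc1cc(/C=N/NC(=O)Nc2ccc(Oc3ccnc(-c4nncn4CCN(C)C)c3)c(F)c2)ccc1O` is not yet measured and differs from compound 1 in one place: 4-hydroxy-3-methoxyphenyl in place of 3-bromophenyl on a carbon with a double bond to nitrogen. The closest guide is compound 3, whose 2,3,4-trimethoxyphenyl group brought a weakening of a 10-fold higher number from compound 1 to compound 3 (1.02 log units; beyond the scatter) and of a 31-fold higher number from compound 2 to compound 3 (1.48 log units; beyond the scatter). The entering group here also carries oxygen substituents, so a weakening of comparable kind, though perhaps smaller, is expected. Compound 4 is estimated at 1500 nM, within 500 nM to 5000 nM. The expected step is a 3.9-fold higher number from compound 1 to compound 4 (0.60 log units; beyond the scatter).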

Compound 4, half-maximal inhibitory concentration: 120 nM
For compound 4 the middle estimate is 13-fold (1.10 log units) above the measured one, outside the stated range (below it).
By their numbers in this assay, from the lowest: compounds 4 and 2 (each within the scatter of the next); then compound 1; then compound 3.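

At this position, oxygen-bearing groups do not all behave alike in this assay: the change to 4-hydroxy-3-methoxyphenyl gives a 3.2-fold lower number from compound 1 to compound 4 (0.50 log units; beyond the scatter) when it replaces 3-bromophenyl, and a 33-fold lower number from compound 3 to compound 4 (1.52 log units; beyond the scatter) when it replaces 2,3,4-trimethoxyphenyl. A halogen on this ring is therefore not required for a low number, and replacing 2,3-dichlorophenyl gives a 1.1-fold lower number from compound 2 to compound 4 (0.03 log units; within the scatter). No measured evidence explains these differences. A 4-hydroxyphenyl or 3-methoxyphenyl group could separate the contributions of the hydroxy and methoxy groups. On these data alone, whether an amine or a carboxylic acid on this ring would keep the number low remains open.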